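Ethylamino to dimethylamino on compound 2

A few compounds are considered here, and "the series" means these few. Any claim that something is new, unique, unknown or untested is made for them only; others in the source may bear on it.

For the measured compounds named here, in a functional assay on MCF7 cells (Homo sapiens) for antiproliferative activity, read by MTT assay, with a stated time of 72 h (a higher number here means a weaker inhibitor, a lower number a stronger inhibitor), compound 2 `CCNc1cc(C)c2cc(NC(=O)c3ccc(Cl)c(Cl)c3)ccc2n1` gives 48600 nM, the highest of the three numbers so far, against compound 1 `CCN1CCN(c2cc(C)c3cc(NC(=O)c4ccc(F)cc4)ccc3n2)CC1` at 4030 nM and compound 3 `CCN1CCN(c2cc(C)c3cc(NC(=O)c4cc(Cl)cc(Cl)c4)ccc3n2)CC1` at 6090 nM. Compound 4 `Cc1cc(N(C)C)nc2ccc(NC(=O)c3ccc(Cl)c(Cl)c3)cc12` has dimethylamino in place of ethylamino on an aromatic carbon, next to the ring nitrogen: dimethylamino in place of ethylamino on an aromatic carbon. Going by the values given here, the only measured step, a 1.5-fold higher number from compound 1 to compound 3 (0.18 log units; within the scatter), sits on a carbonyl carbon rather than at this place, so it offers only weak guidance. Among the compounds with values here, no measured pair isolates a change at this place. The estimated 1.2-fold lower number from compound 2 to compound 4 (0.08 log units; within the scatter) is therefore expected to stay within the scatter. Compound 4 is expected near 40000 nM, with an estimated range from 15000 nM to 90000 nM.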

Compound 4, half-maximal inhibitory concentration: 33300 nM
For compound 4 the middle estimate is 1.2-fold (0.08 log units) above the measured one, within the range that was stated.
By their numbers in this assay, from the lowest: compounds 1 and 3 (each within the scatter of the next); then compounds 4 and 2 (each within the scatter of the next).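

In this assay, the first pair isolating this position gives a 1.5-fold lower number from compound 2 to compound 4 (0.16 log units; within the scatter), so dimethylamino in place of ethylamino on this aromatic carbon leaves the two compounds within the scatter. Going from 1 hydrogen-bond donor to 0 at this place thus shows no reading beyond the scatter in this single pair. Nothing measured here explains this result.

Still open, on these data alone, is whether a longer chain or a carboxylic acid at this place would give a step beyond the scatter. Compound 1 and compound 3 differ from compound 2 in more than one place, so they cannot settle this.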